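A Carbamate in Place of the Aryl Piperazine Cap

The source may hold more compounds than are shown below. What is called first, only, known or untested is meant among the compounds shown, and "the series" means these compounds.

Compound 3 `N#Cc1cccc(COc2ccc(-c3cc(CN4CCN(c5ccc(C(F)(F)F)cc5)CC4)no3)cc2)c1` gives 2000 nM in a functional assay on MCF7 cells (Homo sapiens) for antiproliferative activity, read by sulforhodamine B assay, with a stated time of 72 h (a lower number here means a stronger inhibitor, a higher number a weaker inhibitor), the highest of the three numbers, while compound 2 `FC(F)(F)c1ccc(CN2CCN(Cc3cc(-c4ccc(OCc5cccc(Cl)c5)cc4)on3)CC2)cc1` gives 1400 nM and compound 1 `Cc1ccc(COc2ccc(-c3cc(CN4CCN(Cc5ccc(C(F)(F)F)cc5)CC4)no3)cc2)cc1` gives 1200 nM, both within the scatter of compound 3. Compound 4 `CC(C)(C)OC(=O)N1CCN(Cc2cc(-c3ccc(OCc4cccc(C#N)c4)cc3)on2)CC1` differs from compound 3 in one place: tert-butoxycarbonyl in place of 4-(trifluoromethyl)phenyl on an amine nitrogen in a ring. Among the measured compounds shown here, the only measured step, a 1.2-fold higher number from compound 1 to compound 2 (0.07 log units; within the scatter), altered the benzyl ether side and left the piperazine cap untouched, so no measured step speaks to the present change. Lacking any precedent, the step from compound 3 to compound 4 is expected to raise the number by a 2.5-fold higher number from compound 3 to compound 4 (0.40 log units; beyond the scatter), the aromatic cap being removed. Compound 4 is estimated in this assay at 5000 nM, with a range from 1500 nM to 20000 nM.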

Compound 4, half-maximal inhibitory concentration: 3800 nM
Compound 4: the middle estimate sits 1.3-fold (0.12 log units) above what was measured; low and high end bracket the measured number.
By their numbers in this assay, from the lowest: compounds 1, 2, 3 and 4 (each within the scatter of the next, the first and the last beyond it).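

On the amine nitrogen in the ring, tert-butoxycarbonyl in place of 4-(trifluoromethyl)phenyl gives, in this assay, a 1.9-fold higher number from compound 3 to compound 4 (0.28 log units; within the scatter). Among the compounds shown here, this is the only measured step at this nitrogen, and it shows that, in this pair, a cap with no ring and with hydrogen-bond acceptors stands there without a step beyond the scatter. No measured evidence bears on this result. From the compounds shown here alone, whether an acetyl or a methanesulfonyl group on that nitrogen would also stay within the scatter remains open. So does whether this exchange behaves alike with the 4-methylphenyl and 3-chlorophenyl ethers.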